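An aryl swap at the imine carbon: a flat step expected

The source may hold more compounds than are shown below. What is called first, only, known or untested is meant among the compounds shown, and "the series" means these compounds.

Compound 2 `C/C(=N\Cc1cccnc1)c1c(O)c2ccccc2oc1=O` was tested in an assay on isolated protein for inhibition of myosin-2 (Bos taurus), read by spectrophotometry, with a stated time of 24 min (a lower number here means a stronger inhibitor, a higher number a weaker inhibitor), and gave 17000 nM. Within the data shown here, its only measured neighbour is compound 1 `C/C(=N\CC(C)C)c1c(O)c2ccccc2oc1=O`, which in this assay gave 34000 nM. The step of a 2.0-fold lower number from compound 1 to compound 2 (0.30 log units; within the scatter) lies within the scatter, so the two compounds are not separated by these numbers, and compound 2 stands together with compound 1 rather than apart from it.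

Compound 3 `C/C(=N\Cc1ccccc1C)c1c(O)c2ccccc2oc1=O` has not been measured. It differs from compound 2 by 2-methylphenyl in place of pyridin-3-yl on a saturated chain carbon bound to a double-bonded nitrogen. Among the measured compounds shown here, the one measured step that bears on this place is the exchange of isopropyl for pyridin-3-yl, a 2.0-fold lower number from compound 1 to compound 2 (0.30 log units; within the scatter), which did not move the number beyond the scatter. For the measured compounds named here, with one six-membered aromatic ring of carbon only entering at the same place, and only that single step as a guide, no movement beyond the scatter is expected in this assay; the expected step is a 1.2-fold higher number from compound 2 to compound 3 (0.07 log units; within the scatter). Compound 3 is therefore estimated at 20000 nM, with a range from 8000 nM to 50000 nM.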

Compound 3, half-maximal inhibitory concentration: >= 100000 nM
Compound 3 gave a limit, no number (the forecaster's own chance of this, stated with the estimate: 5%); middle value at least 5.0-fold (0.69 log units) away from the limit.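

In this assay, the place on a saturated chain carbon bound to a double-bonded nitrogen proves not to be indifferent to what enters it: the exchange of isopropyl for pyridin-3-yl had left compound 1 and compound 2 unseparated, whereas 2-methylphenyl in place of pyridin-3-yl gives an at least 5.8-fold higher number from compound 2 to compound 3 (0.76 log units; beyond the scatter). Set against isopropyl, 2-methylphenyl gives an at least 2.9-fold higher number from compound 1 to compound 3 (0.46 log units; beyond the scatter), so compound 3 stands apart from both of its measured neighbours in the same direction, towards the weaker end, and a six-membered aromatic ring in this place does not by itself keep the number where compound 2 has it. The reading of compound 3 is a limit and not a number: the limit of >= 100000 nM in this assay, at which 1 of the 3 values shown sits.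

The step from pyridin-3-yl to 2-methylphenyl changes the ring nitrogen and the methyl group together, and the compounds shown do not tell which of the two goes with the weaker reading, a question that an unsubstituted phenyl in this place would address. They also leave open how a longer chain in this place, or an amine or a carboxylic acid on the aromatic ring, would read in this assay.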